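The source may report more compounds than this note shows. Statements on the series, on what has been measured and on what is new or still open speak of the compounds shown alone.

In an ADME assay on Vero cells (Chlorocebus sabaeus) for cytotoxicity, read by reporter gene assay, with a stated time of 4 days (a higher number here means a weaker inhibitor, a lower number a stronger inhibitor), compound 1 (`CCCCCCCCC(=O)NCC(C)(C)CC1=C(O)C(=O)c2ccccc2C1=O`) gives 16700 nM and compound 2 (`CCCCCCCCCC(=O)NCC(C)(C)CC1=C(O)C(=O)c2ccccc2C1=O`) gives 15000 nM while compound 3 (`CCCCCCCCCCCCCC(=O)NCC(C)(C)CC1=C(O)C(=O)c2ccccc2C1=O`) gives 9810 nM on the same scale. Compound 3 therefore stands within the scatter of both other compounds, and the three do not separate. Compound 4 (`CCCCCCCCCCCCCCCCCC(=O)NCC(C)(C)CC1=C(O)C(=O)c2ccccc2C1=O`) differs from compound 3 in one place (butyl in place of hydrogen on a saturated chain carbon, ten or more bonds along the chain from a carbonyl carbon) with the chain on the shared core carrying butyl in place of hydrogen. Within the data shown here, three measured steps bear on this change: a 1.1-fold lower number from compound 1 to compound 2 (0.05 log units; within the scatter) and a 1.7-fold lower number from compound 1 to compound 3 (0.23 log units; within the scatter) and a 1.5-fold lower number from compound 2 to compound 3 (0.18 log units; within the scatter) with the last being the closest match, since butyl also enters there, nine bonds along the chain from a carbonyl carbon. All three lie within the scatter, so no step beyond the scatter is expected in this assay for this change. The estimated step is a 1.2-fold lower number from compound 3 to compound 4 (0.06 log units; within the scatter) and it is expected to stay within the scatter. For compound 4 the expected value is 8500 nM with an estimated range from 4500 nM to 15000 nM as its likely span.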

Compound 4, half-maximal inhibitory concentration: 5760 nM
Compound 4: the middle estimate sits 1.5-fold (0.17 log units) above what was measured, within the range that was stated.
By their numbers in this assay, from the lowest: compounds 4, 3, 2 and 1 (each within the scatter of the next, the first and the last beyond it).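

In this assay, butyl in place of hydrogen on a saturated chain carbon gives a 1.7-fold lower number from compound 3 to compound 4 (0.23 log units; within the scatter) and so adds no separation on its own. Read across the longer stretch of the same chain, the change does separate the compounds, unlike any earlier step: octyl in place of hydrogen gives a 2.6-fold lower number from compound 2 to compound 4 (0.42 log units; beyond the scatter) and nonyl in place of hydrogen gives a 2.9-fold lower number from compound 1 to compound 4 (0.46 log units; beyond the scatter), both modest in size. No measurement at hand offers an explanation for these steps.

Going by these compounds, whether a longer chain than that of compound 4 would extend these steps remains open. So does the effect of an amine or a carboxylic acid on the chain, since only saturated carbon chains are shown here.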